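A few compounds are considered here, and "the series" means these few. Any claim that something is new, unique, unknown or untested is made for them only; others in the source may bear on it.

Compound 1 `C=C1CN/C(=N/c2ccccc2)S1`: > 100000 nM
Compound 2 `COc1ccc(/C=C2/CN(C)/C(=N/c3ccc(OC)cc3)S2)cc1`: 65900 nM
Compound 3 `C=CC/N=C1/NCC(=C)S1`: > 100000 nM

These results come from an ADME assay on TERT-RPE1 cells (Homo sapiens) for cytotoxicity, read by MTT assay, with a stated time of 72 h; a higher number here means a weaker inhibitor, a lower number a stronger inhibitor. The entries for compound 1 and compound 3 are limits and not numbers: the limit of > 100000 nM in this assay, at which 2 of the 3 values shown sit. Going by the values given here, compound 2 gives 65900 nM, the only true number of the three, so it is the sole reference point.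

Compound 4 `COc1ccc(/C=C2/CN(C)/C(=N/c3ccc(Cl)cc3)S2)cc1` has not yet been measured. It has chloro in place of methoxy on an aromatic carbon, para to a large group: chloro in place of methoxy on an aromatic carbon. Among the compounds with values here, no measured pair shows what this swap does, so, starting from compound 2 at 65900 nM, only a modest move towards a lower number is expected. The expected change is a 1.5-fold lower number from compound 2 to compound 4 (0.17 log units; within the scatter). For compound 4 the estimated value is 45000 nM, with an expected range of 15000 nM to 100000 nM.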

Compound 4, half-maximal inhibitory concentration: 39600 nM
Compound 4: the middle estimate sits 1.1-fold (0.06 log units) above what was measured, within the range that was stated.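

Going by these compounds alone, replacing methoxy with chloro on the aromatic carbon, para to a large group, gives the first readable step in this assay: a 1.7-fold lower number from compound 2 to compound 4 (0.22 log units; within the scatter). This single pair therefore shows no clear difference between the 4-methoxyphenyl and 4-chlorophenyl groups at this position. Compound 1 and compound 3 carry limits, so steps involving them cannot be read: the limit of > 100000 nM in this assay, at which 2 of the 4 values shown sit.

Going by these compounds, it remains open whether an amine or a carboxylic acid here would move the number beyond the scatter. Also open, on these data alone, is what the same swap would do on the other 4-methoxyphenyl group of compound 4.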